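This account rests on a few compounds, and the source may have more. Where it says the series, first, only, none or still open, it means among the compounds named here.

Measured compounds:

- compound 1 `CC(=O)Nc1ccc(O)c(C(=O)/C=C/c2ccc(F)cc2)c1`: in an ADME assay on MT4 cells (Homo sapiens) for cytotoxicity, read by MTT assay, with a stated time of 4 days (on this read-out lower numbers stand for higher toxicity in this test and higher numbers for lower toxicity in this test), compound 1 gives 41100 nM
- compound 2 `CC(=O)Nc1ccc(O)c(C(=O)/C=C/c2ccc(C(F)(F)F)cc2)c1`: in this assay compound 2 gives 21100 nM
- compound 3 `CC(=O)Nc1ccc2oc(-c3cccc(F)c3)cc(=O)c2c1`: in this assay compound 3 gives 240000 nM

Compound 1 and compound 2 share one core and differ at a single place, (trifluoromethyl in place of fluoro on an aromatic carbon). In this assay this gives a 1.9-fold lower number from compound 1 to compound 2 (0.29 log units; within the scatter), so the two numbers are not separated by more than the usual run-to-run variation.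

Compound 3 sits on another core. The difference between the two cores is not broken down here. Its number in this assay is the highest of the three, and the gaps to compound 1 and to compound 2 both lie beyond the scatter.

Compound 4 `CC(=O)Nc1ccc2oc(-c3cccc(C(F)(F)F)c3)cc(=O)c2c1` is not yet measured. It differs from compound 3 by trifluoromethyl in place of fluoro on an aromatic carbon. This is the same kind of change as that from compound 1 to compound 2, not the same: in compound 1 to compound 2 the group sits para to a large group, in compound 3 to compound 4 it sits meta to a large group.

For this assay the step from compound 3 to compound 4 is expected to be a 1.6-fold lower number from compound 3 to compound 4 (0.20 log units; within the scatter), set beside the earlier 1.9-fold lower number from compound 1 to compound 2 (0.29 log units; within the scatter); the expectation rests on that single measured pair and on the high starting number of compound 3. Compound 4 is therefore estimated at 150000 nM, with a likely range of 60000 nM to 400000 nM.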

Compound 4, half-maximal cytotoxic concentration: 10000 nM
The estimate for compound 4 lay 15-fold (1.18 log units) above the measured number, and the stated range ends above it.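

In this assay, trifluoromethyl in place of fluoro on an aromatic carbon does not carry over from one core to the other as a step of fixed size: the same change on two cores in this assay, a 1.9-fold lower number (0.29 log units; within the scatter) from compound 1 to compound 2 and a 24-fold lower number (1.38 log units; beyond the scatter) from compound 3 to compound 4, 12-fold (1.09 log units) apart, beyond the scatter of two such steps

On the core of compound 3 the change gives a 24-fold lower number from compound 3 to compound 4 (1.38 log units; beyond the scatter), a large step towards higher toxicity in this test, so a step read on the core of compound 1 is a poor guide to the size of the step on the core of compound 3. Among these compounds, these notes rest on only two matched pairs, which differ both in core and in where the group sits, with the group meta to a large group in compound 4, so the data do not show whether the core, the placement or both set the gap, and they give no cause for it.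

Still open, from the compounds shown here alone, is whether trifluoromethyl meta to a large group on the core of compound 1 would give a step closer to that seen on the core of compound 3. Going by these compounds, it is also open whether other groups at this place, such as chloro, methoxy, an amine or a carboxylic acid, would move the number on either core as far as trifluoromethyl does on the core of compound 3.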